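From methyl to ethyl on compound 2

A few compounds are considered here, and "the series" means these few. Any claim that something is new, unique, unknown or untested is made for them only; others in the source may bear on it.

Compound 1 `COc1ccc(CN(C(=O)CSc2nc3ccccc3o2)c2cc(OC)c(OC)c(OC)c2)cc1`: 840 nM
Compound 2 `COc1ccc(CN(C(=O)CSC(=S)N2CCN(C)CC2)c2cc(OC)c(OC)c(OC)c2)cc1`: 1250 nM

Going by the values given here, in a functional assay on KYSE-450 cells (Homo sapiens) for inhibition, read by CCK-8 assay, with a stated time of 48 h (a higher number here means a weaker inhibitor, a lower number a stronger inhibitor), compound 2 cannot be told apart from compound 1, since the only measured step is a 1.5-fold higher number from compound 1 to compound 2 (0.17 log units; within the scatter). That step swapped the whole group on the sulfur, yet it stayed within the scatter.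

Compound 3 `CCN1CCN(C(=S)SCC(=O)N(Cc2ccc(OC)cc2)c2cc(OC)c(OC)c(OC)c2)CC1` changes compound 2 in one small way: methyl in place of hydrogen on a saturated chain carbon bound to an amine nitrogen in a ring. This puts methyl in place of hydrogen on a saturated chain carbon bound to an amine nitrogen in a ring, so 4-methylpiperazin-1-yl becomes 4-ethylpiperazin-1-yl.

Among the compounds with values here, no measured pair shows this edit directly, and the one step available is only indirect evidence. As the edit is much smaller than that swap, no shift beyond the scatter is expected in this assay, in either direction. The expected change is a 1.0-fold lower number from compound 2 to compound 3 (0.02 log units; within the scatter). For compound 3 the estimated value is 1200 nM, with an expected range of 600 nM to 2400 nM.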

Compound 3, half-maximal inhibitory concentration: 3070 nM
Beside the measured number, compound 3's estimate is 2.6-fold (0.41 log units) below it; measured number above the stated range.
By their numbers in this assay, from the lowest: compounds 1 and 2 (each within the scatter of the next); then compound 3.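

In this assay, one added methyl on a saturated chain carbon bound to an amine nitrogen in a ring gives a 2.5-fold higher number from compound 2 to compound 3 (0.39 log units; beyond the scatter), so this small edit, turning 4-methylpiperazin-1-yl into 4-ethylpiperazin-1-yl, moves the number beyond the scatter, which the much larger swap of the whole group on the sulfur did not do. That swap stays within the scatter with 4-methylpiperazin-1-yl but not with 4-ethylpiperazin-1-yl, where it gives a 3.7-fold higher number from compound 1 to compound 3 (0.56 log units; beyond the scatter). Nothing available explains the size of this step.

A single step from methyl to ethyl cannot establish a trend at this place. From the compounds shown here alone, whether a longer chain such as propyl, or a 2-hydroxyethyl group, would raise the number further or bring it back down remains open.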